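The source may hold more compounds than are shown below. What is called first, only, known or untested is meant among the compounds shown, and "the series" means these compounds.

Compound 1 `Cc1cccc(/C(N)=N/NC(=S)N2CCN(c3ccccn3)CC2)n1`: 43%
Compound 2 `N/C(=N\NC(=S)N1CCN(c2ccccn2)CC1)c1ccc(F)cn1`: 47.4%
Compound 3 `Cc1cccc(/C(N)=N/NC(=S)N2CCSCC2)n1`: 53.2%

In a functional assay on A-431 cells (Homo sapiens) for cytotoxicity, read by MTT assay, with a stated time of 72 h, tested at 10 uM (on this read-out lower numbers stand for less inhibition of growth and higher numbers for more inhibition of growth at the one concentration tested), compound 3 gives 53.2%, the highest of the three numbers; compound 2 sits within the scatter of it, compound 1 beyond it. Compound 4 `Cc1cccc(/C(N)=N/NC(=S)N2CCCCC2)n1` differs from compound 3 by piperidin-1-yl in place of thiomorpholin-4-yl on a thiocarbonyl carbon. Among the measured compounds shown here, the only measured step, a number 4.4 percentage points higher from compound 1 to compound 2 (within the scatter), swaps the aromatic ring, not the ring on the thiocarbonyl carbon, so it says little about this change. Compound 1 and compound 3 do differ at that ring, and their two values show a modest gap. With so little to go on, the step of a number 4.2 percentage points lower from compound 3 to compound 4 (within the scatter) is expected to stay within the scatter. Compound 4 is therefore estimated at 49%, in a range from 34% to 64%.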

Compound 4, percent growth inhibition at one concentration: 47.8%
Estimate against measurement, compound 4: 1.2 percentage points above, within the range that was stated.
By their numbers in this assay, from the lowest: compounds 1, 2, 4 and 3 (each within the scatter of the next, the first and the last beyond it).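

In this assay, the first step measured at this ring on the thiocarbonyl carbon is a number 5.4 percentage points lower from compound 3 to compound 4 (within the scatter), with piperidin-1-yl in place of thiomorpholin-4-yl. Replacing the ring sulfur of thiomorpholin-4-yl with a carbon therefore leaves the result within the usual scatter, so this one exchange shows no clear effect on growth inhibition. No evidence is available to explain the result. The compounds shown leave open how a morpholin-4-yl ring, with oxygen where thiomorpholin-4-yl has sulfur, would read on this carbon. Going by these compounds, an open-chain group such as diethylamino also remains open.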